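This account rests on a few compounds, and the source may have more. Where it says the series, first, only, none or still open, it means among the compounds named here.

Measured so far:
- compound 1 `c1coc(-c2ccccc2NCC2=NCCN2)c1`: 6.31 nM
- compound 2 `Cc1ccsc1-c1ccccc1NCC1=NCCN1`: 112 nM

Both were run in a functional assay for activation of Alpha-1B adrenergic receptor (Homo sapiens), read by calcium flux; a lower number here means that less compound is needed, a higher number that more compound is needed for the effect. Compound 2 gives the highest number of the two; its nearest neighbour is compound 1, with the step of an 18-fold higher number from compound 1 to compound 2 (1.25 log units; beyond the scatter), a single change of the five-membered ring on the shared core.

Compound 3 `Cc1noc(-c2ccccc2NCC2=NCCN2)n1` is the next variation at the same place: 3-methyl-1,2,4-oxadiazol-5-yl in place of 3-methylthiophen-2-yl on an aromatic carbon. Going by the values given here, only one measured step bears on this kind of change, an 18-fold higher number from compound 1 to compound 2 (1.25 log units; beyond the scatter), and it shows that exchanging the five-membered aromatic ring on this carbon of the core can move the result far beyond the scatter. Among the compounds with values here, no measured compound carries a ring with three hetero atoms here, so the direction is not fixed by the data. A further upward move is expected as the more likely outcome, a 2.7-fold higher number from compound 2 to compound 3 (0.43 log units; beyond the scatter), though a value near compound 2 cannot be excluded. For compound 3 the estimate in this assay is 300 nM, range 60 nM to 1500 nM.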

Compound 3, half-maximal effective concentration: < 5020 nM
Compound 3: no number, only a limit (the forecaster's own chance of this, stated with the estimate: 10%); the middle value does not contradict the limit.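

Compound 3 gives no number, only a limit: the limit of < 5020 nM in this assay, at which 1 of the 3 values shown sits. The steps to compound 3 from compound 1 and from compound 2 therefore cannot be read. Still open, as far as these compounds go, is how 3-methyl-1,2,4-oxadiazol-5-yl compares with furan-2-yl and 3-methylthiophen-2-yl at this place on the shared core.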